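A few compounds are considered here, and "the series" means these few. Any claim that something is new, unique, unknown or untested is made for them only; others in the source may bear on it.

Measured compounds in an assay on isolated protein for inhibition of Rho-associated protein kinase 2 (Homo sapiens), read by a luciferase reporter; a higher number here means a weaker inhibitor, a lower number a stronger inhibitor:
- compound 1 `O=C(Nc1cc2cc[nH]c(=O)c2cc1Cl)C1CNCC1c1ccccn1`, 14 nM
- compound 2 `O=C(Nc1cc2cc[nH]c(=O)c2cc1Cl)[C@@H]1CCCNC1`, 47 nM
- compound 3 `NC(C(=O)Nc1cc2cc[nH]c(=O)c2cc1Cl)c1cccc(Cl)c1`, 15 nM

Compound 1 gives the lowest of the three numbers in this assay. Compound 3 sits closest to it, and the gap between compound 1 and compound 3 lies within the usual scatter, so no order between those two can be read from the numbers. Compound 2 sits furthest away, with a gap that lies beyond the scatter, so compound 2 is read as the weaker inhibitor of that pair.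

The next compound, compound 4 `O=C(Nc1cc2cc[nH]c(=O)c2cc1Cl)C1CNCC1c1ccccc1`, has not been measured. It differs from compound 1 in one place: phenyl in place of pyridin-2-yl on a saturated ring carbon. Among the compounds with values here, no step between two measured compounds shows the effect of exchanging an aromatic ring bearing a nitrogen for one of carbon only at a position like this, so the expectation rests on compound 1 alone. The account expects a small step, if any, from compound 1 to compound 4, not beyond the scatter, as a 1.4-fold higher number from compound 1 to compound 4 (0.15 log units; within the scatter). Compound 4 is therefore estimated at 20 nM, within a range from 7 nM to 60 nM.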

Compound 4, half-maximal inhibitory concentration: 6 nM
Compound 4: middle estimate off by 3.3-fold (0.52 log units), on the high side; the whole stated range lies above it.
By their numbers in this assay, from the lowest: compound 4; then compounds 1 and 3 (each within the scatter of the next); then compound 2.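

In this assay, the step on this saturated ring carbon, with phenyl in place of pyridin-2-yl, is a 2.3-fold lower number from compound 1 to compound 4 (0.37 log units; beyond the scatter), so the ring nitrogen of pyridin-2-yl and its hydrogen-bond acceptor are not needed to hold the number low here. Within the data shown here, the earlier compounds could not show this, since none of them formed a pair differing at this position, and this one pair now gives the first direct reading of an aromatic ring exchange there. No measured evidence is available to explain the direction or size of this step.

As far as these compounds go, whether pyridin-3-yl, pyridin-4-yl or thiophene would behave like phenyl or like pyridin-2-yl remains open. So does the effect of a fluorine, a methoxy group or a nitrile on the phenyl ring of compound 4.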